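A few compounds are considered here, and "the series" means these few. Any claim that something is new, unique, unknown or untested is made for them only; others in the source may bear on it.

Measured compounds:
compound 1, `CCOC(=O)c1[nH]c2cc(Cl)ccc2c1/C=N/NC(=O)CCc1ccccc1`: > 10000 nM
compound 2, `CCOC(=O)c1[nH]c2cc(Cl)ccc2c1/C=N/NC(=O)Cc1ccccc1`: > 10000 nM
compound 3, `CCOC(=O)c1[nH]c2cc(Cl)ccc2c1/C=N/NC(=O)CC1CCCC1`: > 10000 nM

In an assay for inhibition of Polyunsaturated fatty acid lipoxygenase ALOX15 (Homo sapiens), with a stated time of 8 min (on this read-out higher numbers stand for weaker inhibition and lower numbers for stronger inhibition), compound 1 gives > 10000 nM, which is a limit of the assay and not a number. Compound 2 gives > 10000 nM in this assay, likewise a limit. Compound 3 gives > 10000 nM in this assay, again a limit. Compound 1 therefore stands at no readable point on the numbers shown; its value is a limit, and the limit of > 10000 nM in this assay, at which 3 of the 3 values shown sit, is the whole of the evidence for the series. The steps on the saturated chain carbon bound to the carbonyl carbon are a step that the two limits leave unreadable from compound 1 to compound 2, a step that the two limits leave unreadable from compound 1 to compound 3 and a step that the two limits leave unreadable from compound 2 to compound 3, none of them with a readable size.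

Compound 4, `CCOC(=O)c1[nH]c2cc(Cl)ccc2c1/C=N/NC(=O)CCCOc1ccc(Cl)cc1Cl`, differs from compound 1 by (2,4-dichlorophenoxy)methyl in place of phenyl on a saturated chain carbon, two bonds along the chain from a carbonyl carbon. The measured steps sit at a different place on the chain, and none gives a size or a direction, so no step beyond the scatter can be read for compound 4 in this assay in either direction. With every value shown at the limit, compound 4 is expected to sit near the limit as well, the step of a number no higher from compound 1 to compound 4 (the limit leaves the size open) being an estimate only. The estimate for compound 4 in this assay is 10000 nM, within 3000 nM to 30000 nM.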

Compound 4, half-maximal inhibitory concentration: > 10000 nM
Compound 4 was reported as a limit; the forecaster's own chance of this, stated with the estimate: 70%; the middle value lies on the limit itself.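

In this assay compound 4 gives > 10000 nM, a limit of the assay and not a number. Compound 1 also stands at a limit, so no new step can be read between compound 1 and compound 4. The compounds shown leave open which change, if any, to the chain would give a readable value.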